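Anilino aryl swap on the quinazoline-type thioacetamide series

This account rests on a few compounds, and the source may have more. Where it says the series, first, only, none or still open, it means among the compounds named here.

Measured compounds and their numbers in the cell assay:
- compound 1, `O=C(CSc1nc(Nc2ccccc2)c2ccccc2n1)Nc1cccc([N+](=O)[O-])c1`: 17900 nM
- compound 2, `O=C(CSc1nc(Nc2ccccc2)c2ccccc2n1)Nc1ccc(Cl)cc1Cl`: 8410 nM
- compound 3, `C=CC(=O)Nc1cccc(NC(=O)CSc2nc(Nc3ccccc3C)c3ccccc3n2)c1`: 9920 nM

In a functional assay on NCI-H1975 cells (Homo sapiens) for inhibition, read by MTT assay, with a stated time of 72 h (on this read-out higher numbers stand for weaker inhibition and lower numbers for stronger inhibition), compound 1 gives 17900 nM, compound 2 gives 8410 nM and compound 3 gives 9920 nM. Within the data shown here, the one step between measured neighbours is a 2.1-fold lower number from compound 1 to compound 2 (0.33 log units; beyond the scatter), a modest change on the amide-type nitrogen. Compound 3 sits within the usual scatter of both compound 2 and compound 1, so the three numbers cannot be ranked against one another.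

Compound 4, `C=CC(=O)Nc1cccc(NC(=O)CSc2nc(Nc3cccc(OC)c3)c3ccccc3n2)c1`, differs from compound 3 by 3-methoxyphenyl in place of 2-methylphenyl on a nitrogen on an aromatic ring. This is the aryl group on the nitrogen on an aromatic ring, not the amide-type aryl that was varied between compound 1 and compound 2, so that step does not bear on it directly. Among the measured compounds shown here, no measured step touches this position, and the three measured numbers lie close together. The expectation is therefore no step beyond the scatter in this assay, with a 1.0-fold higher number from compound 3 to compound 4 (0.00 log units; within the scatter) as the working figure. Compound 4 is estimated at 10000 nM, with a range from 3500 nM to 30000 nM.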

Compound 4, half-maximal inhibitory concentration: 7940 nM
Compound 4: the middle estimate sits 1.3-fold (0.10 log units) above what was measured, within the range that was stated.
By their numbers in this assay, from the lowest: compounds 4, 2, 3 and 1 (each within the scatter of the next, the first and the last beyond it).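

In this assay, the exchange of 2-methylphenyl for 3-methoxyphenyl on a nitrogen on an aromatic ring gives a 1.2-fold lower number from compound 3 to compound 4 (0.10 log units; within the scatter) and so leaves compound 3 and compound 4 indistinguishable on this read-out. Among these compounds, this is the first reading at this position, which the earlier step on the amide-type nitrogen did not touch, and for this one pair the exchange of aryl groups brings no difference beyond the scatter. The entering group differs from the leaving one both in its substituent and in where that substituent sits on the ring, so this pair cannot separate the two changes, and no measurement at hand bears on the outcome.

Still open, as far as these compounds go, is whether this nitrogen stays as undemanding with groups of another kind, such as a 3-aminophenyl, a 3-carboxyphenyl or a plain butyl chain in place of the aryl group. Among the compounds shown here, also open is what the amide-type aryl group contributes on its own, since compound 2 and compound 3 differ in more than one place and give no step that can be read.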